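The source may report more compounds than this note shows. Statements on the series, on what has been measured and on what is new or still open speak of the compounds shown alone.

The compounds measured so far:

Compound 1, `COc1ccc(-n2cc(CNCCN3CCN(C)CC3)c(-c3ccccc3C)n2)cc1`, in an ADME assay on Huh-7 cells (Homo sapiens) for cytotoxicity (on this read-out higher numbers stand for lower toxicity in this test and lower numbers for higher toxicity in this test), gives > 20000 nM, which is a limit of the assay and not a number.
Compound 2, `CCCN1CCC(CNCc2cn(-c3ccc(C(F)(F)F)cc3)nc2-c2ccc(OC(F)(F)F)cc2)CC1`, gives in this assay 2200 nM.
Compound 3, `CN1CCN(CCNCc2cn(-c3ccc(F)cc3F)nc2-c2ccccc2)CC1`, gives in this assay > 20000 nM, again a limit of the assay rather than a number.

Compound 1 therefore stands at the limit of > 20000 nM in this assay, at which 2 of the 3 values shown sit, and it is not placed relative to the others by a number of its own. Within the data shown here, compound 2 alone gives a measured value; no step between any two of these measured compounds is available, so only the values themselves can be compared.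

Compound 4, `Cc1ccccc1-c1nn(Cc2ccccc2)cc1CNCCN1CCN(C)CC1`, has not yet been tested. It differs from compound 1 by benzyl in place of 4-methoxyphenyl on an aromatic nitrogen. Among the measured compounds shown here, no measured step shows what this change does in this assay. The expected step of a number no higher from compound 1 to compound 4 (the limit leaves the size open) is none beyond the scatter, with compound 4 most likely again at the limit. Compound 4 is estimated at 20000 nM, within a range from 7000 nM to 50000 nM.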

Compound 4, half-maximal cytotoxic concentration: > 20000 nM
Compound 4: no number, only a limit (the forecaster's own chance of this, stated with the estimate: 60%); the middle value sits exactly at the limit.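

Compound 1 and compound 4 both give a limit of the assay rather than a number in this assay, so no step can be read for benzyl in place of 4-methoxyphenyl: the limit of > 20000 nM in this assay, at which 3 of the 4 values shown sit.

The compounds shown leave open whether this change alters the read-out at all.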